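This account rests on a few compounds, and the source may have more. Where it says the series, first, only, none or still open, it means among the compounds named here.

Compound 1, `COC(=O)c1c(-c2ccc([N+](=O)[O-])cc2)oc2ccccc2c1=O`, and compound 2, `COC(=O)c1c(-c2ccc(N)cc2)oc2ccccc2c1=O`, share one core and differ in a single place: amino in place of nitro on an aromatic carbon. In a functional assay on SK-MEL cells (Homo sapiens) for cytotoxicity, read by MTT assay, with a stated time of 6 days (a higher number here means that more compound is needed for the effect, a lower number that less compound is needed), compound 1 gives only a limit of the assay, > 25 ug/mL. Compound 2 likewise gives only a limit, > 25 ug/mL. Between them the step is a step that the two limits leave unreadable from compound 1 to compound 2, so its size stays open.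

Compound 3, `O=c1cc(-c2ccc([N+](=O)[O-])cc2)oc2cc(O)ccc12`, is built on a different core; the difference between the two cores is not broken down here. In this assay compound 3 also gives only a limit, > 25 ug/mL.

Compound 4, `Nc1ccc(-c2cc(=O)c3ccc(O)cc3o2)cc1`, has not yet been measured. It differs from compound 3 by the same change made from compound 1 to compound 2: amino in place of nitro on an aromatic carbon. Among these compounds that change occurs twice.

Compound 4 is expected to land near 30 ug/mL, in a range from 12 ug/mL to 80 ug/mL, because the limit of > 25 ug/mL in this assay, at which 3 of the 3 values shown sit, leaves the earlier step unreadable and offers no measured value that points elsewhere. The step this estimate implies is expected to be a step that the limit leaves unreadable from compound 3 to compound 4.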

Compound 4, concentration for half-maximal effect: 6.59 ug/mL
Beside the measured number, compound 4's estimate is 4.6-fold (0.66 log units) above it, outside the stated range (below it).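

On the core of compound 3, amino in place of nitro on an aromatic carbon gives, in this assay, an at least 3.7-fold lower number from compound 3 to compound 4 (0.57 log units; beyond the scatter), so on this core the amino compound needs less compound for the effect than the nitro compound. From the compounds shown here alone, on the core of compound 1, the same change cannot be read, because neither compound gives a number, only a limit of the assay: the limit of > 25 ug/mL in this assay, at which 3 of the 4 values shown sit. The result therefore does not show that the change carries over from one core to the other, and since compound 3 gives only a limit, the full size of its step also stays unknown.

The compounds shown leave open whether this drop depends on amino itself or would also appear with another group in the same place, such as dimethylamino or an acetamide. They also leave open whether the change would lower the number on any third core.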